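A Urea in Place of the Sulfonamide Group on Compound 2

The source may hold more compounds than are shown below. What is called first, only, known or untested is meant among the compounds shown, and "the series" means these compounds.

Measured so far:
compound 1, `CN1CCN(CCCN(C(=O)Nc2ccc(F)c(Cl)c2)C2CCc3cc(Br)ccc3C2)CC1`, 180 nM
compound 2, `CNS(=O)(=O)c1ccc2c(c1)CC(N(CCCN1CCN(C)CC1)C(=O)Nc1ccc(F)c(Cl)c1)CC2`, 3000 nM

In an assay on CHO cells for binding affinity to melanin-concentrating hormone receptor 1 (Homo sapiens) (on this read-out higher numbers stand for weaker inhibition and lower numbers for stronger inhibition), compound 2 gives 3000 nM, the higher of the two numbers; compound 1 gives 180 nM, a gap well beyond the scatter. Compound 3, `CCNC(=O)Nc1ccc2c(c1)CC(N(CCCN1CCN(C)CC1)C(=O)Nc1ccc(F)c(Cl)c1)CC2`, differs from compound 2 in one place: (ethylcarbamoyl)amino in place of methylsulfamoyl on an aromatic carbon. For the measured compounds named here, no measured pair shows this kind of exchange, so the direction is open. The writer expects a modest lowering for compound 3 in this assay, a step of a 2.0-fold lower number from compound 2 to compound 3 (0.30 log units; within the scatter), close to the scatter. The estimate for compound 3 is 1500 nM, within 400 nM to 6000 nM.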

Compound 3, inhibition constant: 160 nM
Compound 3: middle estimate off by 9.4-fold (0.97 log units), on the high side, outside the stated range (below it).
By their numbers in this assay, from the lowest: compounds 3 and 1 (each within the scatter of the next); then compound 2.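

In this assay the exchange of methylsulfamoyl for (ethylcarbamoyl)amino on the aromatic carbon gives a 19-fold lower number from compound 2 to compound 3 (1.27 log units; beyond the scatter) and so shows that this position responds strongly to the group it carries. For the compounds shown here, this is the first single exchange at this place that can be read, and methylsulfamoyl is clearly not the better of the two groups here. Nothing measured bears on the reason for this step. The compounds shown leave open whether the step depends on the ethyl end of the new group or on the urea itself. They also leave open how a methyl urea, a simple acetamide or a carboxylic acid would fare at this position.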